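The source may report more compounds than this note shows. Statements on the series, on what has been measured and on what is new or still open speak of the compounds shown alone.

Values in a functional assay on NALM-6 cells (Homo sapiens) for cytotoxicity, read by MTT assay, with a stated time of 46 h; on this read-out lower numbers stand for stronger inhibition and higher numbers for weaker inhibition:

- compound 1 `O=C1/C(=C/c2ccncc2)C(c2ccccc2)Oc2ccccc21`: 1600 nM
- compound 2 `O=C1/C(=C/c2ccccc2)C(c2ccccc2)Oc2ccccc21`: 29500 nM
- compound 3 `O=C1/C(=C/c2ccc(Cl)cc2)C(c2ccccc2)Oc2ccccc21`: 7400 nM
- compound 4 `O=C1/C(=C/c2ccc(Br)cc2)C(c2ccccc2)Oc2ccccc21`: not yet measured

Compound 3 stands second highest of the three numbers in this assay, with compound 2 above it and compound 1 below it. The next change is bromo in place of chloro on an aromatic carbon, para to a large group. The same difference, cut one bond further out, reads 4-chlorophenyl to 4-bromophenyl.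

Within the data shown here, no measured step makes this exchange, so the evidence is indirect. The nearest is a 4.0-fold lower number from compound 2 to compound 3 (0.60 log units; beyond the scatter), a modest step for chloro in place of hydrogen at this same place. Further off lie a 4.6-fold higher number from compound 1 to compound 3 (0.67 log units; beyond the scatter), also modest, and an 18-fold higher number from compound 1 to compound 2 (1.27 log units; beyond the scatter), which is large. Both of these replace pyridin-4-yl, a change of a different kind.

Compound 4 keeps a halogen at the place where compound 3 carries one, and the series holds no second halogen to compare. No step beyond the scatter is therefore expected in this assay, and no direction can be favoured. The expected step is a 1.1-fold lower number from compound 3 to compound 4 (0.02 log units; within the scatter). For compound 4 the estimated value is 7000 nM, with an expected range of 3300 nM to 15000 nM.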

Compound 4, half-maximal inhibitory concentration: 6900 nM
Estimate against measurement, compound 4: 1.0-fold (0.01 log units) above; the range from low to high includes it.
By their numbers in this assay, from the lowest: compound 1; then compounds 4 and 3 (each within the scatter of the next); then compound 2.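

In this assay the series now has its first exchange of one halogen for another on this aromatic carbon, para to a large group, and the two halogens cannot be told apart there (a 1.1-fold lower number from compound 3 to compound 4 (0.03 log units; within the scatter)). The step from hydrogen at this place is therefore no longer seen with chloro alone: bromo gives a modest step (a 4.3-fold lower number from compound 2 to compound 4 (0.63 log units; beyond the scatter)) that stays within the scatter of the chloro compound's reading, yet it leaves the 4-bromophenyl compound short of the pyridin-4-yl compound by a modest step of its own (a 4.3-fold higher number from compound 1 to compound 4 (0.63 log units; beyond the scatter)). No measurement on hand speaks to the origin of any of these steps.

Still open, as far as these compounds go, is whether the reading at this place holds only for chloro and bromo or extends to fluoro, iodo, or to a group of another kind, such as methoxy, an amine or a carboxylic acid. Also open, from the compounds shown here alone, is how a substituent on the pyridin-4-yl ring of compound 1, or a change on the phenyl group of the shared core, would read in this assay.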